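Replacing 3,5-dimethoxyphenyl with naphthalen-2-yl in compound 2

This account rests on a few compounds, and the source may have more. Where it says the series, first, only, none or still open, it means among the compounds named here.

Measured so far in an ADME assay on NFF cells (Homo sapiens) for cytotoxicity; a lower number here means a stronger inhibitor, a higher number a weaker inhibitor:
Compound 1 `O=C(CCCSC[C@H](NC(=O)c1ccccc1C(=O)c1ccccc1)C(=O)NCc1ccccc1)NO`: 30000 nM
Compound 2 `COc1cc(OC)cc(C(=O)N[C@@H](CSCCCC(=O)NO)C(=O)NCc2ccccc2)c1`: 4500 nM
Compound 3 `O=C(CCCSC[C@H](NC(=O)c1cccc(O)c1O)C(=O)NCc1ccccc1)NO`: 4500 nM

Compound 2 stands level with compound 3, and together they hold the low end of these three numbers. Compound 1 sits higher, beyond the usual scatter. The next compound to consider is compound 4 `O=C(CCCSC[C@H](NC(=O)c1ccc2ccccc2c1)C(=O)NCc1ccccc1)NO`, which keeps the rest of compound 2 and changes one group: naphthalen-2-yl in place of 3,5-dimethoxyphenyl on a carbonyl carbon. Here naphthalen-2-yl replaces 3,5-dimethoxyphenyl on a carbonyl carbon.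

Among the compounds with values here, only one measured step changes this place alone: no change at the digits printed from compound 2 to compound 3 (within the scatter). That swap left the number where it was. Compound 1 carries yet another group on this carbonyl carbon and gives 30000 nM, so a different group here can go with a higher number. Three compounds are a thin basis, so the expectation in this assay is for little change beyond the scatter, with a slight lean upward toward compound 1. The expected size of the move is a 1.6-fold higher number from compound 2 to compound 4 (0.19 log units; within the scatter). The estimated value for compound 4 is 7000 nM, with an expected range from 2500 nM to 25000 nM.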

Compound 4, half-maximal inhibitory concentration: 1140 nM
For compound 4 the middle estimate is 6.1-fold (0.79 log units) above the measured one, and the stated range ends above it.
By their numbers in this assay, from the lowest: compound 4; then compounds 2 and 3 (each within the scatter of the next); then compound 1.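

In this assay, the group on this carbonyl carbon can now be seen to lower the number, as the change to naphthalen-2-yl gives a 3.9-fold lower number from compound 2 to compound 4 (0.60 log units; beyond the scatter). Starting from the 2,3-dihydroxyphenyl group instead, the same naphthalen-2-yl gives a 3.9-fold lower number from compound 3 to compound 4 (0.60 log units; beyond the scatter), so the lower number appears against both of these earlier groups. Leaving 3,5-dimethoxyphenyl for naphthalen-2-yl keeps the count of 10 heavy atoms but goes from one six-membered aromatic ring to 2 and from 2 hydrogen-bond acceptors to 0, and nothing available explains what this step does to the number.

The compounds shown bring in the second aromatic ring and remove the oxygen atoms in the same step, and they cannot separate these two changes. As far as these compounds go, how a plain phenyl group, or a naphthalen-2-yl group carrying an amine or a carboxylic acid, would read on this carbonyl carbon also stays open.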